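Methoxy for methyl on a cinnamoyl hydrazide series

A few compounds are considered here, and "the series" means these few. Any claim that something is new, unique, unknown or untested is made for them only; others in the source may bear on it.

Compound 1 `Cc1ccc(/C=C/C(=O)NNC(=O)c2ccc3c(c2)OCCO3)cc1` gives 1050 nM in a functional assay on cells (Cancer cell lines, Homo sapiens) for inhibition, read by MTT assay, with a stated time of 48 h; a higher number here means a weaker inhibitor, a lower number a stronger inhibitor. Compound 2 `O=C(/C=C/c1ccc(Br)cc1)NNC(=O)c1ccc2c(c1)OCCO2` gives 2330 nM. Compound 3 `O=C(/C=C/c1ccccc1Cl)NNC(=O)c1ccc2c(c1)OCCO2` gives 4880 nM.

Compound 1 stands at the lowest number of the three, and both of its neighbours lie beyond the scatter from it. Compound 4 `COc1cccc(/C=C/C(=O)NNC(=O)c2ccc3c(c2)OCCO3)c1` differs from it by 3-methoxyphenyl in place of 4-methylphenyl on a double-bonded chain carbon bound to a double-bonded chain carbon. Among the compounds with values here, the steps that bear on this change are a 2.2-fold higher number from compound 1 to compound 2 (0.35 log units; beyond the scatter) and a 4.6-fold higher number from compound 1 to compound 3 (0.67 log units; beyond the scatter); each change away from the 4-methylphenyl of compound 1 gave a modestly higher number, and a 2.1-fold higher number from compound 2 to compound 3 (0.32 log units; beyond the scatter) separates those two. A modest rise is therefore expected for compound 4, though nothing here tells how a methoxy group compares with a halogen. Compound 4 is estimated at 2000 nM, within 900 nM to 4500 nM, a step of a 1.9-fold higher number from compound 1 to compound 4 (0.28 log units; within the scatter).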

Compound 4, half-maximal inhibitory concentration: 170 nM
Compound 4: the middle estimate sits 12-fold (1.07 log units) above what was measured, and the stated range ends above it.
By their numbers in this assay, from the lowest: compound 4; then compound 1; then compound 2; then compound 3.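

The 3-methoxyphenyl on this double-bonded chain carbon is the only change shown that lowers the number from compound 1 (a 6.2-fold lower number from compound 1 to compound 4 (0.79 log units; beyond the scatter)), so the 4-methylphenyl is not the best group tested at this place. The gap to the halogen-bearing phenyl groups is wider still (a 14-fold lower number from compound 2 to compound 4 (1.14 log units; beyond the scatter)) and (a 29-fold lower number from compound 3 to compound 4 (1.46 log units; beyond the scatter)). No measurement at hand accounts for this gain.

Going by these compounds, it remains open whether the gain follows the methoxy group itself or where it sits on the phenyl ring. On these data alone, it is also open whether a hydroxyl or an amine on that ring would keep it.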